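Chloro to methoxy on a cytotoxic fluoroquinolone core

The source may hold more compounds than are shown below. What is called first, only, known or untested is meant among the compounds shown, and "the series" means these compounds.

Compound 1 `O=C(O)c1cn(C2CC2)c2c(Cl)c(N3CCCC3)c(F)cc2c1=O`: 150 ug/mL
Compound 2 `COc1c(N2CCCC2)c(F)cc2c(=O)c(C(=O)O)cn(C3CC3)c12`: 150 ug/mL
Compound 3 `CNCC1(C)CCN(c2c(F)cc3c(=O)c(C(=O)O)cn(C4CC4)c3c2Cl)C1`: 23 ug/mL

These three compounds were measured in a functional assay on V79 cells (Cricetulus griseus) for cytotoxicity, read by colony formation; a higher number here means a weaker inhibitor, a lower number a stronger inhibitor. The change methoxy in place of chloro on an aromatic carbon gave no change at the digits printed from compound 1 to compound 2 (within the scatter). The change 3-methyl-3-((methylamino)methyl)pyrrolidin-1-yl in place of pyrrolidin-1-yl on an aromatic carbon gave a 6.5-fold lower number from compound 1 to compound 3 (0.81 log units; beyond the scatter). Compound 4 `CNCC1(C)CCN(c2c(F)cc3c(=O)c(C(=O)O)cn(C4CC4)c3c2OC)C1` is not yet measured; it differs from compound 3 by methoxy in place of chloro on an aromatic carbon. This is the same kind of change as that from compound 1 to compound 2, but its surroundings differ: in compound 2 the place is ortho to a pyrrolidin-1-yl group, in compound 4 it is ortho to a 3-methyl-3-((methylamino)methyl)pyrrolidin-1-yl group. Because no change at the digits printed from compound 1 to compound 2 (within the scatter) showed no change, the step of no change at the digits printed from compound 3 to compound 4 (within the scatter) is expected to be small as well. Compound 4 is therefore estimated at 23 ug/mL in this assay, expected between 12 ug/mL and 45 ug/mL.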

Compound 4, half-maximal inhibitory concentration: 120 ug/mL
The estimate for compound 4 lay 5.2-fold (0.72 log units) below the measured number, and the stated range ends below it.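

In this assay, methoxy in place of chloro gave a 5.2-fold higher number from compound 3 to compound 4 (0.72 log units; beyond the scatter), so the flat result seen on the first core did not carry over to the second: the same change on two cores in this assay, no change at the digits printed (within the scatter) from compound 1 to compound 2 and a 5.2-fold higher number (0.72 log units; beyond the scatter) from compound 3 to compound 4, 5.2-fold (0.72 log units) apart, beyond the scatter of two such steps

Read the other way, 3-methyl-3-((methylamino)methyl)pyrrolidin-1-yl in place of pyrrolidin-1-yl gave a 1.3-fold lower number from compound 2 to compound 4 (0.10 log units; within the scatter), so this change did not carry over either: the same change on two cores in this assay, a 6.5-fold lower number (0.81 log units; beyond the scatter) from compound 1 to compound 3 and a 1.3-fold lower number (0.10 log units; within the scatter) from compound 2 to compound 4, 5.2-fold (0.72 log units) apart, beyond the scatter of two such steps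

Each change therefore depends on the group present at the other place, but two pairs of compounds cannot show why this happens or whether it extends beyond this set.

Going by these compounds, it remains open how an ethoxy group or a bromo group would behave in place of chloro. On these data alone, it also remains open whether a piperazine in place of the pyrrolidine would show the same dependence.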